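Replacing the butoxy group of compound 2 with hydrogen

A few compounds are considered here, and "the series" means these few. Any claim that something is new, unique, unknown or untested is made for them only; others in the source may bear on it.

Of the compounds shown here, three sharing one core have been tested in a functional assay on A549 cells (Homo sapiens) for antiproliferative activity, read by MTT assay, with a stated time of 48 h; on this read-out lower numbers stand for stronger inhibition and higher numbers for weaker inhibition. Compound 1 `COc1ccc(/C=C/c2cc(OC)cc(OC)c2/C=C/C(=O)c2cccc(OC)c2)cc1` gives 6.1 ug/mL. Compound 2 `CCCCOc1ccc(C(=O)/C=C/c2c(/C=C/c3ccc(OC)cc3)cc(OC)cc2OC)cc1` gives 8.7 ug/mL, the highest of the three numbers, though a 1.4-fold higher number from compound 1 to compound 2 (0.15 log units; within the scatter) lies within the scatter. Among the compounds with values here, compound 3 `COc1ccc(/C=C/c2cc(OC)cc(OC)c2/C=C/C(=O)c2ccc(N)cc2)cc1` gives 3.8 ug/mL, and a 2.3-fold lower number from compound 2 to compound 3 (0.36 log units; beyond the scatter) is the only step here that goes beyond it.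

Compound 4 `COc1ccc(/C=C/c2cc(OC)cc(OC)c2/C=C/C(=O)c2ccccc2)cc1` has not yet been measured. It differs from compound 2 in one place: hydrogen in place of butoxy on an aromatic carbon

Within the data shown here, two measured steps bear on this change. Exchanging the butoxy-bearing ring for the methoxy-bearing ring of compound 1 produced a 1.4-fold higher number from compound 1 to compound 2 (0.15 log units; within the scatter), a shift within the scatter, whereas exchanging butoxy for amino produced a 2.3-fold lower number from compound 2 to compound 3 (0.36 log units; beyond the scatter). Removing the butoxy group altogether is therefore expected to leave the number of compound 4 close to that of compound 2, with at most a small move toward lower numbers, so that a 1.3-fold lower number from compound 2 to compound 4 (0.13 log units; within the scatter) is the step anticipated in this assay. On that basis compound 4 is estimated at 6.5 ug/mL, within a range from 3.5 ug/mL to 12 ug/mL.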

Compound 4, half-maximal inhibitory concentration: 3.9 ug/mL
For compound 4 the middle estimate is 1.7-fold (0.22 log units) above the measured one, and the stated range covers the measured number.
By their numbers in this assay, from the lowest: compounds 3, 4, 1 and 2 (each within the scatter of the next, the first and the last beyond it).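

In this assay, removing the butoxy group gives a step beyond the scatter, a 2.2-fold lower number from compound 2 to compound 4 (0.35 log units; beyond the scatter), so this position needs no substituent for the lower number to be reached. The plain phenyl ring cannot be told apart from the rings carrying amino, a 1.0-fold higher number from compound 3 to compound 4 (0.01 log units; within the scatter), or methoxy, a 1.6-fold lower number from compound 1 to compound 4 (0.19 log units; within the scatter), so the earlier step from butoxy to amino now reads as compound 2 standing apart from compound 3 and compound 4 rather than as a gain specific to amino, although compound 2 remains within the scatter of compound 1. Nothing available here accounts for the difference between butoxy and hydrogen at this position.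

On these data alone, it remains open whether an ethoxy group or a chain longer than butoxy would follow compound 2 or compound 4. As far as these compounds go, a carboxylic acid or a fluorine atom in the same place is equally open.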